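Isopropyl for dimethylamino on the aryl hydrazone

This account rests on a few compounds, and the source may have more. Where it says the series, first, only, none or still open, it means among the compounds named here.

Compound 1, `O=C(CCN1CCN(c2ccnc3cc(Cl)ccc23)CC1)N/N=C/c1c[nH]c2ccccc12`: 43.3%
Compound 2, `CN(C)c1ccc(/C=N/NC(=O)CCN2CCN(c3ccnc4cc(Cl)ccc34)CC2)cc1`: 94.2%

Of the compounds shown here, two with a shared core have been measured in a physicochemical assay for inhibition, read by spectrophotometry, with a stated time of 24 h, tested at 2.5 mM; a higher number here means more inhibition at the concentration tested (going by the name of the read-out), a lower number less inhibition. Compound 2 gives 94.2%, the higher of the two numbers, and compound 1 gives 43.3%. Within the data shown here, the single measured step, a number 50.9 percentage points higher from compound 1 to compound 2 (beyond the scatter), arises from 4-(dimethylamino)phenyl in place of 1H-indol-3-yl on a carbon with a double bond to nitrogen.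

Compound 3, `CC(C)c1ccc(/C=N/NC(=O)CCN2CCN(c3ccnc4cc(Cl)ccc34)CC2)cc1`, has not yet been measured. It differs from compound 2 as follows: isopropyl in place of dimethylamino on an aromatic carbon. Among the measured compounds shown here, no measured step swaps these two groups, so the step to compound 3 is not covered directly. The one step shown, a number 50.9 percentage points higher from compound 1 to compound 2 (beyond the scatter), tells only that a change at this end of the molecule can move this assay by a large amount. Since compound 2 stands near the top of the scale, an estimated step of a number 34.2 percentage points lower from compound 2 to compound 3 (beyond the scatter) is expected, pointing downward with wide uncertainty. Compound 3 is therefore estimated at 60%, within a range from 30% to 90%.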

Compound 3, a percentage reported as inhibition, at one concentration (the size of the read-out at that concentration, not a potency): 94%
For compound 3 the middle estimate is 34 percentage points below the measured one; the measured number lies above the stated range.
By their numbers in this assay, from the lowest: compound 1; then compounds 3 and 2 (each within the scatter of the next).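

In this assay, among these compounds, isopropyl in place of dimethylamino on an aromatic carbon para to a large group gives a number 0.2 percentage points lower from compound 2 to compound 3 (within the scatter), so this read-out does not separate the two groups at this position, even though the hydrogen-bond acceptor counted on dimethylamino has no counterpart on isopropyl. The large gain seen earlier is therefore not tied to dimethylamino alone: 4-isopropylphenyl in place of 1H-indol-3-yl gives a number 50.7 percentage points higher from compound 1 to compound 3 (beyond the scatter), and both phenyl compounds now stand well clear of compound 1. No measurement of any property of these groups is available to account for this.

The compounds shown leave open whether a bare hydrogen, a methoxy group or a carboxylic acid on this same aromatic carbon would keep the number where compound 2 and compound 3 have it, or whether the number stays level only with groups of this size. They also leave open whether an unsubstituted phenyl in place of 1H-indol-3-yl would already give most of the large step.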